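Extending the piperazine: from compound 2 to compound 4

The source may hold more compounds than are shown below. What is called first, only, known or untested is meant among the compounds shown, and "the series" means these compounds.

Compound 2 `Cc1ccc(-c2nnc(-c3ccc(CN4CCN(C)CC4)c(C(F)(F)F)c3)o2)cc1Nc1nccc(-c2cccnc2)n1` gives 50 nM in a functional assay on HL-60 cells (Homo sapiens) for inhibition, read by MTT assay, with a stated time of 72 h (a higher number here means a weaker inhibitor, a lower number a stronger inhibitor), and so stands at the lowest of the two numbers shown, set against compound 1 `Cc1ccc(-c2nnc(-c3ccc(CN4CCN(C)CC4)cc3)o2)cc1Nc1nccc(-c2cccnc2)n1`, which in this assay gives 570 nM. For the measured compounds named here, the step of an 11-fold lower number from compound 1 to compound 2 (1.06 log units; beyond the scatter) is the only change that was measured directly. Compound 3 `Cc1ccc(-c2nnc(-c3cc(C(F)(F)F)cc(C(F)(F)F)c3)o2)cc1Nc1nccc(-c2cccnc2)n1` in this assay reaches only > 30000 nM, which is a limit of the assay and not a number (the limit of > 30000 nM in this assay, at which 1 of the 3 values shown sits). Compound 4 `Cc1ccc(-c2nnc(-c3ccc(CN4CCN(CCN)CC4)c(C(F)(F)F)c3)o2)cc1Nc1nccc(-c2cccnc2)n1` differs from compound 2 by aminomethyl in place of hydrogen on a saturated chain carbon bound to an amine nitrogen in a ring. Going by the values given here, no measured step touches this part of the molecule; the one measured step concerns trifluoromethyl on an aromatic carbon and was large, whereas the present change sits on the saturated chain carbon bound to the ring amine nitrogen. The account therefore expects the step of a 1.2-fold higher number from compound 2 to compound 4 (0.08 log units; within the scatter) from compound 2 to compound 4 to stay within the scatter. Compound 4 is expected to give 60 nM in this assay, with a range from 20 nM to 200 nM.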

Compound 4, half-maximal inhibitory concentration: 20 nM
The estimate for compound 4 lay 3.0-fold (0.48 log units) above the measured number; the range from low to high includes it.
By their numbers in this assay, from the lowest: compound 4; then compound 2; then compound 1. At a limit, above all of these: compound 3.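

In this assay, for the compounds shown here, the change from methyl to 2-aminoethyl gives a 2.5-fold lower number from compound 2 to compound 4 (0.40 log units; beyond the scatter), so the number does respond to a change on this saturated chain carbon bound to an amine nitrogen in a ring, which no earlier step had touched. This modest step is smaller than the one made on the aromatic carbon, an 11-fold lower number from compound 1 to compound 2 (1.06 log units; beyond the scatter), and the two sit at different places on the molecule. Nothing at hand accounts for the step from compound 2 to compound 4.

It remains open whether the amine or the chain alone carries this step, since ethyl and 2-hydroxyethyl do not appear among these compounds. Also open, going by these compounds, are whether a longer chain such as 3-aminopropyl would move the number further, and whether 2-aminoethyl would give a similar step on compound 1, which lacks the trifluoromethyl.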